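Cytotoxicity of piperidinyl-piperidine sulfonamides: a thiazole replaces a pyridine

The source may report more compounds than this note shows. Statements on the series, on what has been measured and on what is new or still open speak of the compounds shown alone.

The compounds measured so far in an ADME assay on HCT-116 cells (Homo sapiens) for cytotoxicity, read by CellTiter-Glo, with a stated time of 72 h; a lower number here means a stronger inhibitor, a higher number a weaker inhibitor:
Compound 1, `CCc1ccc(S(=O)(=O)N2CCC(N3CCC(C)CC3)CC2)cc1`: > 5000 nM
Compound 2, `CC1CCN(C2CCN(S(=O)(=O)c3cccnc3Cl)CC2)CC1`: > 10000 nM

Compound 1 gives only a limit of this assay, > 5000 nM, and no number. Compound 2 likewise gives only a limit of this assay, > 10000 nM. Within the data shown here, the one step between them, a step that the two limits leave unreadable from compound 1 to compound 2, cannot be read in size, since both ends sit at limits; the evidence is the limit of > 10000 nM in this assay, at which 1 of the 2 values shown sits, and (the limit of > 5000 nM in this assay, at which 1 of the 2 values shown sits). Compound 2 therefore stands at a limit of this assay, with nothing that places it above or below compound 1.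

Compound 3, `Cc1nc(Cl)sc1S(=O)(=O)N1CCC(N2CCC(C)CC2)CC1`, has not yet been measured in this assay. It differs from compound 2 in one place: 2-chloro-4-methyl-1,3-thiazol-5-yl in place of 2-chloropyridin-3-yl on a sulfonyl sulfur. Among the measured compounds shown here, the only measured step that touches the same position, the group on the sulfonyl sulfur, is the step from compound 1 to compound 2, and its size is unreadable. No measured change in this series has yet produced a readable number. The expectation is therefore that compound 3 shows no step beyond the scatter, a step that the limit leaves unreadable from compound 2 to compound 3, and again sits at a limit rather than a number. Compound 3 is estimated at 15000 nM, within 5000 nM to 50000 nM.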

Compound 3, half-maximal inhibitory concentration: > 10000 nM
Compound 3: no number, only a limit; the forecaster's own chance of this, stated with the estimate: 80%; the middle value lies beyond the limit too.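

Compound 3 gives only a limit (> 10000 nM) and no number. With compound 1, compound 2 and compound 3 all at limits, none of the steps among them can be read in size: the limit of > 10000 nM in this assay, at which 2 of the 3 values shown sit.

The compounds shown leave open whether any group on the sulfonyl sulfur gives a readable number, and how these three compounds rank.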